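The compounds below may be only part of what the source reports. "The series", "measured", "known", "first", "only" and "open" are said of these compounds alone.

Measured so far in a functional assay (cardiac atrium) for agonist activity, with Cavia porcellus as the target; a higher number here means that more compound is needed for the effect, a lower number that less compound is needed:
- compound 1 `CCO/C(O)=C1\C(C)=NC(C)=C([N+](=O)[O-])C1c1ccncc1`: 6460 nM
- compound 2 `CC1=NC(C)=C([N+](=O)[O-])C(c2ccncc2)/C1=C(\O)OC(C)C`: 8050 nM

Compound 2 has the highest of the two numbers in this assay, and the step of a 1.2-fold higher number from compound 1 to compound 2 (0.10 log units; within the scatter) lies within the scatter, so the two compounds are not separated. Compound 3 `COCCO/C(O)=C1\C(C)=NC(C)=C([N+](=O)[O-])C1c1ccncc1` differs from compound 2 by 2-methoxyethyl in place of isopropyl on an oxygen on an unsaturated carbon. Among the compounds with values here, only the step from compound 1 to compound 2 bears on this change, as it alters the same position, and it produced no shift beyond the scatter. No step beyond the scatter is therefore expected for compound 3 in this assay; the estimate is 7000 nM with range 2500 nM to 20000 nM, a step of a 1.2-fold lower number from compound 2 to compound 3 (0.06 log units; within the scatter).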

Compound 3, half-maximal effective concentration: 37700 nM
Compound 3: middle estimate off by 5.4-fold (0.73 log units), on the low side; the whole stated range lies below it.
By their numbers in this assay, from the lowest: compounds 1 and 2 (each within the scatter of the next); then compound 3.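

In this assay, this position proves sensitive to the group on the oxygen on an unsaturated carbon: a 4.7-fold higher number from compound 2 to compound 3 (0.67 log units; beyond the scatter) and a 5.8-fold higher number from compound 1 to compound 3 (0.77 log units; beyond the scatter) both lie beyond the scatter, unlike the earlier step. The higher number goes with 2-methoxyethyl, so a small change in this chain can matter here. No evidence at hand gives a cause for the shift.

On these data alone, whether the chain oxygen or the chain itself carries the shift stays open, since 2-methoxyethyl differs from isopropyl in both. A butyl chain or a chain ending in an amine could separate these readings.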